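The compounds below may be only part of what the source reports. "The series", "measured", "known", "first", "only" and "open" are said of these compounds alone.

Among the measured compounds shown here, in an ADME assay on microsomes from liver (Homo sapiens) for metabolic stability, read by LC-MS, using NADPH, with a stated time of 10 min, tested at 0.1 uM (a higher number here means faster removal of the compound, a lower number slower removal), compound 2 (`O=C(NCCCCn1cccn1)c1cccc(C2SCC(=O)N2c2ccccn2)c1`) gives 82.1 mL.min-1.g-1 and is the lowest of the three numbers so far. Compound 3 (`O=C(NCCCCc1ccccc1)c1cccc(C2SCC(=O)N2c2ccccn2)c1`) gives 412 mL.min-1.g-1 and compound 1 (`COc1ccccc1N1C(=O)CSC1c1cc(F)cc(C(=O)NCCCCc2ccccc2)c1`) gives 2080 mL.min-1.g-1 in the same test. Compound 4 (`O=C(NCCCCn1cccn1)c1cccc(C2SCC(=O)N2c2cc(F)ccn2)c1`) differs from compound 2 in one place only: fluoro in place of hydrogen on an aromatic carbon. Pyridin-2-yl thus becomes 4-fluoropyridin-2-yl, with the fluoro opposite the ring nitrogen.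

For the measured compounds named here, the one measured step, a 5.0-fold higher number from compound 2 to compound 3 (0.70 log units; beyond the scatter), swaps 1H-pyrazol-1-yl for phenyl on the chain, a different part of the molecule, so it gives no direct guide to this change. Compound 1 also carries a fluoro group, but it differs from compound 3 in more than that, so its number cannot be read for fluoro alone. Going by the values given here, with no measured step for fluoro in place of hydrogen, no step beyond the scatter is expected in this assay. The expected step is a 1.2-fold higher number from compound 2 to compound 4 (0.09 log units; within the scatter) as an estimate only. For compound 4 the estimated value is 100 mL.min-1.g-1 with an expected range from 45 mL.min-1.g-1 to 220 mL.min-1.g-1 as a deliberately wide margin.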

Compound 4, intrinsic clearance in microsomes in the Homo sapiens assay: 116 mL.min-1.g-1
Compound 4: the middle estimate sits 1.2-fold (0.06 log units) below what was measured, and the stated range covers the measured number.
By their numbers in the Homo sapiens assay, from the lowest: compounds 2 and 4 (each within the scatter of the next); then compound 3; then compound 1.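

In the Homo sapiens assay compound 2 gives 82.1 mL.min-1.g-1 and compound 4 gives 116 mL.min-1.g-1, and fluoro in place of hydrogen on this aromatic carbon, opposite the ring nitrogen, gives a 1.4-fold higher number from compound 2 to compound 4 (0.15 log units; within the scatter), so this read-out does not separate the two compounds, whereas the swap on the chain gave a 5.0-fold higher number from compound 2 to compound 3 (0.70 log units; beyond the scatter) in the same test. In a physicochemical assay for solubility, read by turbidimetry, measured as kinetic solubility, at pH 6.8 (on this read-out higher numbers stand for higher solubility and lower numbers for lower solubility), compound 2 gives 50000 nM and compound 4 gives 50000 nM, and the same pair shows no change at the digits printed from compound 2 to compound 4 (within the scatter), so that read-out does not separate them either. Nothing measured here gives a reason for this result.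

Going by these compounds, whether a chloro, a methoxy or an amine on this same carbon would move the clearance number beyond the scatter remains open, as does the effect of fluoro on another carbon of this ring. On these data alone, it is also open whether the same fluoro would give a similarly small step in compound 3, which carries phenyl on its chain.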